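The source may report more compounds than this note shows. Statements on the series, on what has been measured and on what is new or still open speak of the compounds shown alone.

Within the data shown here, in a functional assay on MCF7 cells (Homo sapiens) for antiproliferative activity, read by MTT assay, with a stated time of 72 h (on this read-out lower numbers stand for stronger inhibition and higher numbers for weaker inhibition), compound 1 `COc1ccc(-c2ccc3ncn(-c4cc(OC)c(OC)c(OC)c4)c3c2)cc1F` gives 520 nM, the lowest number of the three measured so far. Compound 2 `COc1cc(-n2cnc3ccc(-c4cc(F)ccc4F)cc32)cc(OC)c1OC` gives 6420 nM, the highest, and compound 3 `COc1cc(-n2cnc3ccc(-c4cccc(F)c4)cc32)cc(OC)c1OC` sits between them at 2350 nM. Compound 4 `COc1cc(-n2cnc3ccc(-c4ccc(Cl)cc4Cl)cc32)cc(OC)c1OC` has not yet been measured. It carries 2,4-dichlorophenyl in place of 3-fluorophenyl on an aromatic carbon. The closest guide is the modest 2.7-fold lower number from compound 2 to compound 3 (0.44 log units; beyond the scatter), which links the 2,5-difluorophenyl group to the 3-fluorophenyl group. Read in reverse, it suggests a higher number for compound 4. The trend is not general: the modest 4.5-fold higher number from compound 1 to compound 3 (0.66 log units; beyond the scatter) and the large 12-fold higher number from compound 1 to compound 2 (1.09 log units; beyond the scatter) show that compound 1, with its 3-fluoro-4-methoxyphenyl group, goes against any rule that more substitution on this phenyl raises the number. Among the measured compounds shown here, no measured compound carries chlorine, so a modest rise in this assay is the most that can be expected. The expected change is a 1.9-fold higher number from compound 3 to compound 4 (0.28 log units; within the scatter). The estimated value for compound 4 is 4500 nM, in a range from 1500 nM to 12000 nM.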

Compound 4, half-maximal inhibitory concentration: 5420 nM
Compound 4: middle estimate off by 1.2-fold (0.08 log units), on the low side; the range from low to high includes it.
By their numbers in this assay, from the lowest: compound 1; then compound 3; then compounds 4 and 2 (each within the scatter of the next).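

Replacing 3-fluorophenyl with 2,4-dichlorophenyl at this position in this assay gives a 2.3-fold higher number from compound 3 to compound 4 (0.36 log units; beyond the scatter), the first sign of how chlorine behaves here. Exchanging 2,5-difluorophenyl for 2,4-dichlorophenyl gives a 1.2-fold lower number from compound 2 to compound 4 (0.07 log units; within the scatter), so these two dihalogenated phenyl groups cannot be told apart, and the change of halogen together with its placement has no readable effect in this pair. Both sit above the 3-fluorophenyl compound, but a link between two substituents and a higher number fails for compound 1, whose 3-fluoro-4-methoxyphenyl group also carries two substituents, as a 10-fold higher number from compound 1 to compound 4 (1.02 log units; beyond the scatter) shows.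

Nothing given here explains these differences. Going by these compounds, it remains open whether the methoxy group of compound 1 could be replaced by a hydroxyl, an amine or a carboxylic acid with the number staying low.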